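Aryloxy substituent variation in the maximal electroshock series

The source may report more compounds than this note shows. Statements on the series, on what has been measured and on what is new or still open speak of the compounds shown alone.

Among the measured compounds shown here, compound 1 `CCCOc1ccc2c(c1)C(=O)NCCO2` gives 78.3 mg/kg in a functional assay on the whole organism with Mus musculus as the target, in the maximal electroshock model, with stated times of 30 min and 4 h (a lower number here means that less compound is needed, a higher number that more compound is needed for the effect), and stands highest of the two numbers measured so far; compound 2 `CCCCCCCOc1ccc2c(c1)C(=O)NCCO2` gives 19 mg/kg. For the measured compounds named here, the single measured step, a 4.1-fold lower number from compound 1 to compound 2 (0.62 log units; beyond the scatter), is the only one that bears on the change now considered. Compound 3 `O=C1NCCOc2ccc(OCc3cccc(F)c3)cc21` carries 3-fluorophenyl in place of ethyl on a saturated chain carbon bound to an oxygen on an aromatic ring. Since the step from compound 1 to compound 2 went to a lower number beyond the scatter, a lowering of comparable size is expected, a 3.6-fold lower number from compound 1 to compound 3 (0.55 log units; beyond the scatter). Compound 3 is therefore estimated at 22 mg/kg, with a range from 8 mg/kg to 55 mg/kg.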

Compound 3, dose for half-maximal effect: 73.1 mg/kg
Estimate against measurement, compound 3: 3.3-fold (0.52 log units) below; measured number above the stated range.
By their numbers in this assay, from the lowest: compound 2; then compounds 3 and 1 (each within the scatter of the next).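

Replacing ethyl with 3-fluorophenyl on a saturated chain carbon bound to an oxygen on an aromatic ring leaves the number unchanged within the scatter (a 1.1-fold lower number from compound 1 to compound 3 (0.03 log units; within the scatter)). The lowering seen with the longer chain of compound 2 therefore does not extend to this aromatic group, and the hexyl group keeps the lower number (a 3.8-fold higher number from compound 2 to compound 3 (0.59 log units; beyond the scatter)). At this place, chain and aromatic ring are not interchangeable, even though both add heavy atoms.

No evidence bears on why these groups differ. On these data alone, whether an unsubstituted phenyl, a longer chain than hexyl or a terminal amine would lower the number remains open.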